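A few compounds are considered here, and "the series" means these few. Any claim that something is new, unique, unknown or untested is made for them only; others in the source may bear on it.

Among the measured compounds shown here, in a functional assay on MCF7 cells (Homo sapiens) for inhibition, read by CCK-8 assay, with a stated time of 48 h (a higher number here means a weaker inhibitor of growth, a lower number a stronger inhibitor of growth), only two compounds have numbers so far. Compound 1 `CN1CCN(c2ccc(Nc3ncc(Cl)c(NCc4ccccc4)n3)nc2)CC1` gives 17300 nM, and compound 2 `CCc1ccc(Nc2nc(Nc3ccc(N4CCN(C)CC4)cn3)ncc2Cl)cc1` gives 8230 nM, the lower of the two. Compound 3 `CC(C)c1ccc(Nc2nc(Nc3ccc(N4CCN(C)CC4)cn3)ncc2Cl)cc1` differs from compound 2 in one place: methyl in place of hydrogen on a saturated chain carbon bound to an aromatic carbon and a saturated chain carbon. This methyl in place of hydrogen turns ethyl to isopropyl, so 4-ethylphenyl becomes 4-isopropylphenyl. For the measured compounds named here, no measured step touches the ethyl group itself. Going by the values given here, the only step that bears on the change is a 2.1-fold lower number from compound 1 to compound 2 (0.32 log units; beyond the scatter), which put 4-ethylphenyl in place of benzyl on a nitrogen on an aromatic ring and was modest, though just beyond the scatter. The present change is smaller, so a step within the scatter is expected, with no firm direction. For compound 3 the estimated value is 7500 nM, with an expected range of 3800 nM to 15000 nM. The estimate thus expects a 1.1-fold lower number from compound 2 to compound 3 (0.04 log units; within the scatter).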

Compound 3, concentration for 50% growth inhibition: 1880 nM
For compound 3 the middle estimate is 4.0-fold (0.60 log units) above the measured one; measured number below the stated range.
By their numbers in this assay, from the lowest: compound 3; then compound 2; then compound 1.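

The methyl that turns ethyl to isopropyl brings, in this assay and with the rest of the molecule unchanged, a 4.4-fold lower number from compound 2 to compound 3 (0.64 log units; beyond the scatter) and so shows that growth inhibition responds to a single added carbon on this saturated chain carbon. The 4-isopropylphenyl group in place of benzyl on a nitrogen on an aromatic ring gives a 9.2-fold lower number from compound 1 to compound 3 (0.96 log units; beyond the scatter) and widens the spread seen so far among these groups on that nitrogen. Nothing available explains why one methyl has this effect.

The compounds shown leave open whether the trend continues with tert-butyl or cyclopropyl at this place, or with a longer chain such as propyl. They also leave open how a methoxy group or a carboxylic acid in place of isopropyl would read.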